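Removing one methyl from compound 1: an expected cytotoxicity

The compounds below may be only part of what the source reports. "The series", "measured", "known", "first", "only" and "open" are said of these compounds alone.

Measured compounds:
compound 1 `COc1cc(/C=N/NC(=O)COc2cccc3ccccc23)cc(OC)c1OC` — >= 20 ug/mL
compound 2 `COc1ccc(/C=N/NC(=O)COc2cccc3ccccc23)cc1OC` — >= 20 ug/mL
compound 3 `C/C(=N\NC(=O)COc1cccc2ccccc12)c1ccccc1O` — 20 ug/mL

In an ADME assay on HEL cells (Homo sapiens) for cytotoxicity (a lower number here means that less compound is tolerated, a higher number that more compound is tolerated), compound 1 gives >= 20 ug/mL, which is a limit of the assay and not a number. Compound 2 likewise gives >= 20 ug/mL, again a limit. For the measured compounds named here, compound 3 is the only one with a measured number, giving 20 ug/mL. Among the three, two values therefore sit at the limit of >= 20 ug/mL in this assay, at which 2 of the 3 values shown sit, so compound 1 stands at that limit and nowhere more precise.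

Going by the values given here, the only step between measured compounds that differ in one place is a step that the two limits leave unreadable from compound 1 to compound 2; with both ends at limits, its size cannot be read.

Compound 4 `COc1cc(/C=N/NC(=O)COc2cccc3ccccc23)cc(OC)c1O` differs from compound 1 by hydrogen in place of methyl on an oxygen on an aromatic ring. Among the compounds with values here, no measured step removes a methyl from an oxygen, so no measured step bears directly on this change, and the one step that exists is unreadable. The available numbers give no reason to expect compound 4 to move beyond the scatter, and a step of a number no higher from compound 1 to compound 4 (the limit leaves the size open) is therefore expected. Compound 4 is estimated at 20 ug/mL in this assay, in the range 10 ug/mL to 40 ug/mL, most likely again reported only as a limit.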

Compound 4, minimum cytotoxic concentration in the HEL assay: 100 ug/mL
Compound 4: the middle estimate sits 5.0-fold (0.70 log units) below what was measured, and the stated range ends below it.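

For the compounds shown here, in the HEL assay the value of compound 1 is a limit and not a number, so no step to compound 4 can be read: the limit of >= 20 ug/mL in the HEL assay, at which 2 of the 4 values shown sit.

In a physicochemical assay for lipophilicity, measured as octanol-water partition (on this read-out lower numbers stand for lower lipophilicity and higher numbers for higher lipophilicity), compound 1 gives 3.26 and compound 4 gives 3.23. In the physicochemical assay this is a number 0.03 log units lower from compound 1 to compound 4 (within the scatter).

The compounds shown leave open how far compound 1 actually lies from compound 4 in the HEL assay.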